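Bromo on the benzyl group in a pyrimidine–naphthyl series

The source may hold more compounds than are shown below. What is called first, only, known or untested is meant among the compounds shown, and "the series" means these compounds.

Measured compounds:
- compound 1, `CCCCCCn1cc(COc2ccc(-c3cc(-c4cccc5ccccc45)nc(N)n3)c(O)c2)nn1`: "not determined" (no result reported)
- compound 2, `Nc1nc(-c2ccc(OCc3cn(Cc4ccccc4)nn3)cc2O)cc(-c2cccc3ccccc23)n1`: 71300 nM

Compound 1 carries a hexyl chain on the triazole, and in an ADME assay on cells (Macrophage) for cytotoxicity, read by resazurin assay, with a stated time of 48 h (a lower number here means that less compound is tolerated, a higher number that more compound is tolerated), compound 1 gives "not determined" (no result reported). Compound 2 replaces that chain with a benzyl group; in this assay compound 2 gives 71300 nM. Within the data shown here, this is the only number available, so compound 2 stands alone and no ranking or trend can be read from the data.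

Compound 3, `Nc1nc(-c2ccc(OCc3cn(Cc4ccc(Br)cc4)nn3)cc2O)cc(-c2cccc3ccccc23)n1`, is the next point. It differs from compound 2 in one place: bromo in place of hydrogen on an aromatic carbon. Among the measured compounds shown here, no measured step exists for this kind of change, so its size in this assay is not known from the data.

The expectation for compound 3 is a small step, if any, from compound 2, likely within or only slightly beyond the scatter of the method. The step from compound 2 to compound 3 is estimated as a 1.4-fold lower number from compound 2 to compound 3 (0.15 log units; within the scatter). For compound 3 in this assay the estimate is 50000 nM, with a range from 20000 nM to 130000 nM.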

Compound 3, half-maximal cytotoxic concentration: > 100000 nM
Compound 3: no number, only a limit (the forecaster's own chance of this, stated with the estimate: 25%); middle value at least 2.0-fold (0.30 log units) away from the limit.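

The value of compound 3 in this assay is a limit of the assay and not a number: the limit of > 100000 nM in this assay, at which 1 of the 3 values shown sits.

Among these compounds, the change from benzyl to 4-bromobenzyl provides the first measured step, an at least 1.4-fold higher number from compound 2 to compound 3 (0.14 log units; that floor lies within the scatter), and so the first reading of any change at this position on the aromatic ring, since compound 1 offers no number for comparison with compound 2. The data show no fall in the tolerated concentration when bromo enters para to the large group, but because the floor of the step lies within the scatter, compound 2 and compound 3 are not separated and the true size of the step has no upper bound.

Open, going by these compounds, is whether this reading is specific to bromo or would also hold for a smaller halogen such as fluoro or chloro, or for a methoxy group, an amine or a carboxylic acid at the same carbon. Also open, on these data alone, is how bromo would read at another carbon of this ring, and what a longer chain between the triazole and the aromatic ring would do in this assay.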